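From benzyloxycarbonyl to phenylsulfonyl on a ring nitrogen

This account rests on a few compounds, and the source may have more. Where it says the series, first, only, none or still open, it means among the compounds named here.

Compound 1 `COc1ccc(/C=C2\CCC=CC2=O)cc1` gives 1620 nM
Compound 2 `CCOc1ccc(/C=C2\CCC=CC2=O)cc1OC` gives 600 nM
Compound 3 `COc1cc(/C=C2\CN(C(=O)OCc3ccccc3)C=CC2=O)cc(OC)c1OC` gives 24200 nM

In a functional assay on MDA-MB-231 cells (Homo sapiens) for antiproliferative activity, read by sulforhodamine B assay, with a stated time of 72 h (a lower number here means a stronger inhibitor, a higher number a weaker inhibitor), compound 3 gives 24200 nM and stands highest of the three numbers, with compound 1 giving 1620 nM and compound 2 giving 600 nM. Both gaps from compound 3 lie beyond the scatter. Compound 4 `COc1cc(/C=C2\CN(S(=O)(=O)c3ccccc3)C=CC2=O)cc(OC)c1OC` carries phenylsulfonyl in place of benzyloxycarbonyl on an amine nitrogen in a ring. Going by the values given here, no pair of measured compounds shows this change, so nothing measured sizes it. A moderate fall in this assay beyond the scatter is expected (a 4.0-fold lower number from compound 3 to compound 4 (0.61 log units; beyond the scatter)), resting on little more than the room left below compound 3 (24200 nM). For compound 4 the estimated value is 6000 nM (expected range 1200 nM to 30000 nM).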

Compound 4, half-maximal inhibitory concentration: 23300 nM
For compound 4 the middle estimate is 3.9-fold (0.59 log units) below the measured one; low and high end bracket the measured number.
By their numbers in this assay, from the lowest: compound 2; then compound 1; then compounds 4 and 3 (each within the scatter of the next).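

In this assay, benzyloxycarbonyl and phenylsulfonyl on the amine nitrogen in a ring cannot be told apart, with a 1.0-fold lower number from compound 3 to compound 4 (0.02 log units; within the scatter) as the first step read at this position. At this nitrogen, then, the two groups serve equally, and the link to the aromatic ring can differ without a visible effect on this number. No measurement offers a reason for this.

From the compounds shown here alone, what stays open is how this nitrogen would behave carrying only hydrogen, a small methyl or acetyl group, or a basic aminoalkyl chain. Also open, going by these compounds, is whether a substituent on the phenylsulfonyl ring, such as fluorine or methoxy, would separate the two groups.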